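Ester variation on the shared core: cytotoxicity notes

The source may report more compounds than this note shows. Statements on the series, on what has been measured and on what is new or still open speak of the compounds shown alone.

Measured compounds:
compound 1 `CC(C)C(=O)OCCc1c(-c2ccccc2Cl)c2cc(Cl)ccc2[nH]c1=O` — 62000 nM
compound 2 `O=C(O)CCCC(=O)OCCc1c(-c2ccccc2Cl)c2cc(Cl)ccc2[nH]c1=O` — 110000 nM
compound 3 `O=C(OCCc1c(-c2ccccc2Cl)c2cc(Cl)ccc2[nH]c1=O)C1CCCCC1` — 38000 nM

In an ADME assay on HepG2 2.2.15 cells (Homo sapiens) for cytotoxicity (a lower number here means that less compound is tolerated, a higher number that more compound is tolerated), compound 2 gives the largest number of the three, though its gap to compound 1, a 1.8-fold higher number from compound 1 to compound 2 (0.25 log units; within the scatter), is within the scatter; only compound 3, reached by a 2.9-fold lower number from compound 2 to compound 3 (0.46 log units; beyond the scatter), lies beyond it. Compound 4 `O=C(/C=C/c1ccccc1)OCCc1c(-c2ccccc2Cl)c2cc(Cl)ccc2[nH]c1=O` differs from compound 2 by 2-phenylethenyl in place of 3-carboxypropyl on a carbonyl carbon. Going by the values given here, the step bearing on this is the one from compound 2 to compound 3, where a ring replaced the 3-carboxypropyl on the carbonyl carbon and the number fell modestly; the step of a 1.6-fold lower number from compound 1 to compound 3 (0.21 log units; within the scatter), within the scatter, points the same way but weakly. A modest fall in this assay is therefore expected for compound 4, of about a 2.8-fold lower number from compound 2 to compound 4 (0.44 log units; beyond the scatter). The estimate for compound 4 is 40000 nM, with a range from 15000 nM to 110000 nM.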

Compound 4, half-maximal cytotoxic concentration: 230000 nM
Compound 4: the middle estimate sits 5.8-fold (0.76 log units) below what was measured, and the stated range ends below it.
By their numbers in this assay, from the lowest: compounds 3, 1 and 2 (each within the scatter of the next, the first and the last beyond it); then compound 4.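

In this assay, 2-phenylethenyl on this carbonyl carbon gives a higher number than each earlier group: a 2.1-fold higher number from compound 2 to compound 4 (0.32 log units; beyond the scatter), a 3.7-fold higher number from compound 1 to compound 4 (0.57 log units; beyond the scatter) and a 6.1-fold higher number from compound 3 to compound 4 (0.78 log units; beyond the scatter). A ring here therefore does not by itself go with a lower number, as the cyclohexyl of compound 3 and the 2-phenylethenyl of compound 4 stand well apart. Nothing available explains this rise. As far as these compounds go, whether the aromatic ring or the double bond of 2-phenylethenyl goes with the higher number remains open. So does the outcome with a saturated 2-phenylethyl chain or an amine on this carbonyl carbon.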